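Swapping one ring group on a low-toxicity compound

The source may hold more compounds than are shown below. What is called first, only, known or untested is meant among the compounds shown, and "the series" means these compounds.

Compound 1 `C=C1CC[C@@H]2[C@](C)(COC(=O)c3ccco3)[C@H](OC(=O)c3ccco3)CC[C@@]2(C)[C@@H]1/C=C/C1=CCOC1=O`: 1110000 nM
Compound 2 `C=C1CC[C@@H]2[C@](C)(COC(=O)c3ccccc3C(=O)O)[C@H](OC(=O)c3ccccc3C(=O)O)CC[C@@]2(C)[C@@H]1/C=C/C1=CCOC1=O`: > 1620000 nM
Compound 3 `C=C1CC[C@@H]2[C@](C)(COC(=O)CCC(=O)O)[C@H](OC(=O)CCC(=O)O)CC[C@@]2(C)[C@@H]1C/C=C1\C=COC1=O`: 32000 nM

All three compounds were tested in an ADME assay on HepG2 2.2.15 cells (Homo sapiens) for cytotoxicity, read by MTT assay; on this read-out lower numbers stand for higher toxicity in this test and higher numbers for lower toxicity in this test. In this test, compound 1 gives 1110000 nM and compound 3 gives 32000 nM. Compound 2 reads > 1620000 nM, which is a limit and not a number. On these results, compound 2 stands at the low-toxicity end alongside compound 1, well clear of compound 3.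

Compound 4 `C=C1CC[C@@H]2[C@](C)(COC(=O)c3ccccc3C(=O)O)[C@H](OC(=O)c3ccccc3C(=O)O)CC[C@@]2(C)[C@@H]1C/C=C1\C=COC1=O` keeps the ester groups of compound 2 and differs in one place: a group of 8 heavy atoms (6 carbon, 2 oxygen; one five-membered non-aromatic ring with 1 hetero atom) in place of a group of 8 heavy atoms (6 carbon, 2 oxygen; one five-membered non-aromatic ring with 1 hetero atom), on a saturated ring carbon. The same atoms are joined differently, on a saturated ring carbon. For the measured compounds named here, compound 3 is the only tested compound carrying the entering group, and its ester groups are different. Going by the values given here, no measured step separates these two changes. With compound 3 at 32000 nM, a clear move towards higher toxicity is expected, though probably not the whole distance. The expected change is an at least 10-fold lower number from compound 2 to compound 4 (1.03 log units; beyond the scatter). Compound 4 is estimated at 150000 nM, with an expected range of 30000 nM to 1000000 nM.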

Compound 4, half-maximal cytotoxic concentration: > 2040000 nM
Compound 4 gave a limit, no number; the forecaster's own chance of this, stated with the estimate: 20%; middle value at least 13-fold (1.13 log units) from the limit.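

In this assay, compound 2 and compound 4 each gave only a limit and not a number, and the step between them cannot be read. The compounds shown leave open whether swapping the ring group changes this read-out at all with these ester groups in place.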